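Cyclopentyl urea following the ethyl urea of compound 3

This account rests on a few compounds, and the source may have more. Where it says the series, first, only, none or still open, it means among the compounds named here.

Of the three compounds measured in a functional assay on HT-1080 cells (Homo sapiens) for antiproliferative activity, read by sulforhodamine B assay, with a stated time of 48 h (a lower number here means a stronger inhibitor, a higher number a weaker inhibitor), compound 3 `CCNC(=O)Nc1ccc(S(=O)(=O)Oc2ccccc2C(C)C)cc1` gives 250 nM, the lowest number of the three. Compound 2 `CC(C)C(=O)Nc1ccc(S(=O)(=O)Oc2ccccc2C(C)C)cc1` gives 4900 nM and compound 1 `CCCCCC(=O)Nc1ccc(S(=O)(=O)Oc2ccccc2C(C)C)cc1` gives 6300 nM; the steps of a 25-fold lower number from compound 1 to compound 3 (1.40 log units; beyond the scatter) and a 20-fold lower number from compound 2 to compound 3 (1.29 log units; beyond the scatter) are large, whereas a 1.3-fold lower number from compound 1 to compound 2 (0.11 log units; within the scatter) lies within the scatter. Compound 4 `CC(C)c1ccccc1OS(=O)(=O)c1ccc(NC(=O)NC2CCCC2)cc1` differs from compound 3 by cyclopentyl in place of ethyl on an amide-type nitrogen. The measured step that bears on this exchange of one alkyl group for another is a 1.3-fold lower number from compound 1 to compound 2 (0.11 log units; within the scatter), which stayed within the scatter; the large steps concerned the move from an amide to a urea, which compound 4 keeps. A step of no change at the digits printed from compound 3 to compound 4 (within the scatter) in this assay is therefore expected, within the scatter. Compound 4 is estimated at 250 nM, with a range from 80 nM to 800 nM.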

Compound 4, half-maximal inhibitory concentration: 3900 nM
Compound 4: middle estimate off by 16-fold (1.19 log units), on the low side; measured number above the stated range.
By their numbers in this assay, from the lowest: compound 3; then compounds 4, 2 and 1 (each within the scatter of the next).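

On the amide-type nitrogen, the urea alone does not hold the low number of compound 3: in this assay cyclopentyl in place of ethyl gives a 16-fold higher number from compound 3 to compound 4 (1.19 log units; beyond the scatter) and this large step shows that the group on that nitrogen matters. The urea of compound 4 also sits level with the two amides, with a 1.3-fold lower number from compound 2 to compound 4 (0.10 log units; within the scatter) and a 1.6-fold lower number from compound 1 to compound 4 (0.21 log units; within the scatter) both within the scatter. Nothing measured here accounts for this loss.

The compounds shown leave open whether the ring itself or the larger number of carbons goes with the higher number. A straight butyl chain or a cyclopropyl on that nitrogen would separate the two.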